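The source may hold more compounds than are shown below. What is called first, only, known or untested is meant among the compounds shown, and "the series" means these compounds.

Of the compounds shown here, two have so far been tested in an ADME assay on HeLa cells (Homo sapiens) for cytotoxicity, read by ATP content, with a stated time of 3 days; on this read-out lower numbers stand for higher toxicity in this test and higher numbers for lower toxicity in this test. Compound 1 has the structure `COc1ccc(-n2c(=O)n(Cc3cc4cc(Cl)ccc4n3CCCC#N)c3cnccc32)c(F)c1`. In this assay compound 1 gives > 50000 nM, which is a limit of the test rather than a measured number. Compound 2 has the structure `CC(C)CCn1c(Cn2c(=O)n(C3CC3)c3ccncc32)nc2ccncc21`. In this assay compound 2 gives > 100000 nM, again a limit and not a number. Going by the values given here, compound 1 therefore stands only at a limit, namely (the limit of > 50000 nM in this assay, at which 1 of the 2 values shown sits), and the one further value shown is also a limit, (the limit of > 100000 nM in this assay, at which 1 of the 2 values shown sits), so no measured number exists on either side of it.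

Compound 3, with the structure `Cc1ccc(-n2c(=O)n(Cc3cc4cc(Cl)ccc4n3CCCC#N)c3cnccc32)cc1`, has not yet been measured. It differs from compound 1 in one place: 4-methylphenyl in place of 2-fluoro-4-methoxyphenyl on an aromatic nitrogen. Among the compounds with values here, no step between two measured compounds is available, so the effect of this change on cytotoxicity cannot be read from the data. Since compound 1 gives only > 50000 nM, compound 3 is expected to show no cytotoxicity within the tested range either. The step that the limit leaves unreadable from compound 1 to compound 3 is expected to be none beyond the scatter. Compound 3 is estimated at 70000 nM, with a range from 30000 nM to 200000 nM, and most likely reported again only as a limit.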

Compound 3, half-maximal cytotoxic concentration: > 50000 nM
Compound 3 ended at the assay's limit; the forecaster's own chance of this, stated with the estimate: 85%; the middle value does not contradict the limit.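

No step can be read from compound 1 to compound 3, because each stands only at a limit and not at a measured number: the limit of > 50000 nM in this assay, at which 2 of the 3 values shown sit.

The compounds shown leave open whether replacing 2-fluoro-4-methoxyphenyl with 4-methylphenyl changes toxicity at all, and whether compound 1, compound 2 or compound 3 would give a measurable number in this assay.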